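This account rests on a few compounds, and the source may have more. Where it says the series, first, only, none or still open, it means among the compounds named here.

Series notes, cytotoxicity read-out on one cell line.

Of the compounds shown here, three carry numbers so far. Compound 1 `COc1ccc(-c2cc(/C=C/C(=O)c3ccc(N)cc3)[nH]n2)cc1` in a functional assay on NCI-H522 cells (Homo sapiens) for cytotoxicity, read by sulforhodamine B assay, with a stated time of 48 h, tested at 0.1 uM (on this read-out lower numbers stand for a stronger effect and higher numbers for a weaker effect at the one concentration tested), gives 85%. Compound 2 `COc1ccc(C(=O)/C=C/c2cc(-c3cc(OC)c(OC)c(OC)c3)n[nH]2)cc1OC` in this assay gives 91%, and compound 3 `COc1ccc(C(=O)/C=C/c2cc(-c3cc(OC)c(OC)c(OC)c3)n[nH]2)cc1` in this assay gives 87%. Compound 1 holds the lowest of the three numbers, yet its gap to compound 3 and its gap to compound 2 both lie within the usual scatter, so the three compounds are not told apart on this read-out.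

Within the data shown here, the one single-point step recorded so far, a number 4 percentage points lower from compound 2 to compound 3 (within the scatter), removes a methoxy group from an aromatic carbon and stays within the scatter.

The next compound, compound 4 `COc1ccc(-c2cc(/C=C/C(=O)c3ccc(N)cc3)[nH]n2)cc1OC`, is reached from compound 1 by the change (methoxy in place of hydrogen on an aromatic carbon). This is the mirror of the step between compound 2 and compound 3, only on the other aryl ring of the shared core. Since that step stayed within the scatter, no step beyond the scatter is expected in this assay here either, in either direction.

For compound 4 a value of 87% is expected in this assay, within 77% to 97%. The step thus expected is a number 2 percentage points higher from compound 1 to compound 4 (within the scatter), a number flat within the scatter.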

Compound 4, a percentage reported as activity, at one concentration (the size of the read-out at that concentration, not a potency): 95%
The estimate for compound 4 lay 8 percentage points below the measured number; the measured number falls inside the stated range.
By their numbers in this assay, from the lowest: compounds 1, 3, 2 and 4 (each within the scatter of the next).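

In this assay, methoxy in place of hydrogen on an aromatic carbon, ortho to a methoxy group and meta to a large group, gives a number 10 percentage points higher from compound 1 to compound 4 (within the scatter). The change has now been read on two cores, and the two steps agree within the scatter: the same change on two cores in this assay, a number 4 percentage points lower (within the scatter) from compound 2 to compound 3 and a number 10 percentage points lower (within the scatter) from compound 4 to compound 1, 6 percentage points apart, within the scatter of two such steps On this read-out, hydrogen and methoxy at this position are therefore not told apart on the core of compound 1, and the same holds for the step on the core shared by compound 2 and compound 3.

The compounds shown leave open whether another group at this position, such as a hydroxyl group, a fluorine atom or an amine, would give a step beyond the scatter. They also leave open whether any of these compounds would separate from the others at a concentration other than the single one read here.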